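This account rests on a few compounds, and the source may have more. Where it says the series, first, only, none or still open, it means among the compounds named here.

Compound 1 `O=C1Nc2ccc(C(=O)c3ccco3)cc2/C1=C/c1cc(Br)cc(Br)c1`: 16%
Compound 2 `COc1c(Br)cc(/C=C2\C(=O)Nc3ccc(C(=O)c4ccco4)cc32)cc1Br`: -12.6%
Compound 3 `O=C1Nc2ccc(C(=O)c3ccco3)cc2/C1=C/c1ccc(O)c(C(F)(F)F)c1`: 9.5%

In an assay on HeLa cells for inhibition of Kinesin-like protein KIF15 (Homo sapiens), read by microscopy, with stated times of 2 s and 20 s, tested at 750 nM (on this read-out lower numbers stand for less inhibition and higher numbers for more inhibition at the one concentration tested (going by the name of the read-out)), compound 1 gives 16%, the highest of the three numbers. Compound 3 gives 9.5%, which sits within the usual scatter of the number for compound 1. Compound 2 gives -12.6%, the furthest away. Going by the values given here, the only measured single change is a number 28.6 percentage points lower from compound 1 to compound 2 (beyond the scatter), a modest drop beyond the scatter.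

Compound 4 `O=C1Nc2ccc(C(=O)c3ccco3)cc2/C1=C/c1ccncc1` has not yet been measured. It differs from compound 1 in one place: pyridin-4-yl in place of 3,5-dibromophenyl on a double-bonded chain carbon bound to a double-bonded ring carbon. Among the compounds with values here, no measured step concerns this kind of change, since the step from compound 1 to compound 2 alters only a methoxy group elsewhere and so does not bear on it. The nearest guide is compound 3, which carries a different ring at the same place as compound 1 and gives a number within the scatter of it. The expectation is therefore no step beyond the scatter, a number 11 percentage points lower from compound 1 to compound 4 (beyond the scatter). For compound 4 the estimate is 5%, expected to fall between -15% and 25%.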

Compound 4, a percentage reported as inhibition, at one concentration (the size of the read-out at that concentration, not a potency): 0.8%
Compound 4: the middle estimate sits 4.2 percentage points above what was measured; measured number inside the range.
By their numbers in this assay, from the lowest: compound 2; then compounds 4, 3 and 1 (each within the scatter of the next, the first and the last beyond it).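

In this assay, putting pyridin-4-yl in place of 3,5-dibromophenyl on a double-bonded chain carbon bound to a double-bonded ring carbon gives a number 15.2 percentage points lower from compound 1 to compound 4 (beyond the scatter). This is the first step shown at this position, and it shows that the read-out responds to a change of the ring placed there, though only modestly. The step removes both bromine atoms and brings in a ring nitrogen at once, and nothing shown here explains the drop or separates those two parts of the change.

Going by these compounds, it remains open whether a plain phenyl ring at this position would read closer to compound 1 or to compound 4, which would help to separate the bromine atoms from the ring nitrogen. On these data alone, how a phenyl ring carrying an amine or a carboxylic acid would behave here is also open.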